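A few compounds are considered here, and "the series" means these few. Any claim that something is new, unique, unknown or untested is made for them only; others in the source may bear on it.

Compound 1 `N=C(NCCCc1c[nH]cn1)NCCCC(c1ccccc1)c1ccccn1`: 251 nM; compound 2 `N=C(NCCCc1c[nH]cn1)NCCC(c1ccccc1)c1ccccn1`: 97.7 nM.

Of the two measured compounds, compound 2 stands at the lower number in a functional assay on ileum for antagonist activity at histamine H1 receptor (Cavia porcellus) (on this read-out lower numbers stand for tighter binding and higher numbers for weaker binding), and compound 1 gives a number that is higher by more than the usual scatter. Compound 3 `N=C(NCCCc1c[nH]cn1)NCCC(c1ccc(F)cc1)c1ccccn1` differs from compound 2 by fluoro in place of hydrogen on an aromatic carbon. Among the measured compounds shown here, no step between measured compounds is available to guide this change, so only a small move is expected in this assay, if any, toward a lower number. Compound 3 is therefore estimated at 60 nM, within a range from 20 nM to 200 nM, an expected step of a 1.6-fold lower number from compound 2 to compound 3 (0.21 log units; within the scatter).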

Compound 3, dissociation constant: 22.4 nM
Estimate against measurement, compound 3: 2.7-fold (0.43 log units) above; measured number inside the range.
By their numbers in this assay, from the lowest: compound 3; then compound 2; then compound 1.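

In this assay the change from phenyl to 4-fluorophenyl gives a 4.4-fold lower number from compound 2 to compound 3 (0.64 log units; beyond the scatter) and so shows that this aromatic carbon, para to a large group, responds to a single fluoro by more than the usual scatter. The earlier compounds shown here offered no such single change at this position. No measurement shown explains this step.

Open, on these data alone, is whether chloro, methoxy or trifluoromethyl at this same carbon would give a lower or a higher number, and whether fluoro on compound 1 would bring a step of similar size.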